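Stilbene-to-aryl swap in a bile acid receptor series

The compounds below may be only part of what the source reports. "The series", "measured", "known", "first", "only" and "open" are said of these compounds alone.

Measured compounds:
compound 1 `COC(=O)/C=C/c1cccc(N(Cc2ccc(/C=C/c3c(F)cccc3F)cc2)C(=O)C(C)C)c1`, 108 nM
compound 2 `COC(=O)/C=C/c1cccc(N(Cc2ccc(-c3cccc(OC)c3)cc2)C(=O)NC(C)C)c1`, 1370 nM
compound 3 `COC(=O)/C=C/c1cccc(N(Cc2ccc(-c3ccc(C)cc3)cc2)C(=O)NC(C)C)c1`, 449 nM

In an assay on isolated protein with Bile acid receptor (Homo sapiens) as the target (a higher number here means that more compound is needed for the effect, a lower number that less compound is needed), compound 1 gives the lowest of the three numbers; compound 3 is nearest, and compound 2 furthest. Within the data shown here, compounds 2 and 3 share their core but carry an aryl group where compound 1 carries 2-(2,6-difluorophenyl)ethenyl, and they also differ from compound 1 in the amide portion, so no single measured step covers the change to compound 4. Among the measured compounds shown here, the only one-place step on record, a 3.1-fold lower number from compound 2 to compound 3 (0.48 log units; beyond the scatter), shows that exchanging the substituent on the distal ring moves the readout modestly.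

Compound 4 `COC(=O)/C=C/c1cccc(N(Cc2ccc(-c3ccc(N(C)C)cc3)cc2)C(=O)C(C)C)c1` keeps the amide portion of compound 1 and makes this change: 4-(dimethylamino)phenyl in place of 2-(2,6-difluorophenyl)ethenyl on an aromatic carbon. The two aryl analogues compound 2 and compound 3 both sit well above compound 1, which suggests the aryl replacement itself costs some potency, though the amide difference blurs that reading. Compound 4 is therefore expected to give a somewhat higher number than compound 1, an estimated step of a 2.8-fold higher number from compound 1 to compound 4 (0.44 log units; beyond the scatter). The estimate for compound 4 is 300 nM, within 80 nM to 1200 nM.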

Compound 4, half-maximal effective concentration: 57 nM
Compound 4: the middle estimate sits 5.3-fold (0.72 log units) above what was measured, outside the stated range (below it).
By their numbers in this assay, from the lowest: compounds 4 and 1 (each within the scatter of the next); then compound 3; then compound 2.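

In this assay, the change on an aromatic carbon para to a large group gives a 1.9-fold lower number from compound 1 to compound 4 (0.28 log units; within the scatter), so 4-(dimethylamino)phenyl and 2-(2,6-difluorophenyl)ethenyl cannot be told apart at this position. Among these compounds, this is the first reading of the change with the amide portion of compound 1 held constant, which compound 2 and compound 3 could not give: the double bond outside the aromatic rings and both fluorine atoms leave, a nitrogen enters, and the number stays within the scatter. Nothing measured for these compounds accounts for this result.

Still open is how much of the distance between compound 1 and compounds 2 and 3 belongs to the amide portion, a question no pair shown can settle. Also open, going by these compounds, is whether the dimethylamino group itself contributes, which unsubstituted phenyl or 4-methylphenyl on the amide portion of compound 1 would test, and how a carboxylic acid in place of the methyl ester would read.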